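Replacing the nitro group of compound 2

This account rests on a few compounds, and the source may have more. Where it says the series, first, only, none or still open, it means among the compounds named here.

Of the compounds shown here, three have been measured in a toxicity assay on Huh-7.5 cells (Homo sapiens) for inhibition, read by MTT assay, with a stated time of 96 h; a higher number here means that more compound is tolerated, a lower number that less compound is tolerated. Here compound 1 `COc1ccc(C(=O)Nc2ccc(N(C)C)cc2)cc1[N+](=O)[O-]` gives 88200 nM, compound 2 `CC(C)Oc1ccc(C(=O)Nc2ccc(N(C)C)cc2)cc1[N+](=O)[O-]` gives 50000 nM, and compound 3 `COc1ccc(NC(=O)c2ccc(OC(C)C)c([N+](=O)[O-])c2)cc1` gives 23400 nM. Among these three, compound 2 has compound 1 as its nearest neighbour and compound 3 as its furthest.

The next structure, compound 4 `CCC(=O)Nc1cc(C(=O)Nc2ccc(N(C)C)cc2)ccc1OC(C)C`, is made from compound 2 by one change: propanoylamino in place of nitro on an aromatic carbon. In words, this is propanoylamino in place of nitro on an aromatic carbon, ortho to an isopropoxy group. Neither measured step touches that place, so they bear on the question only indirectly. Isopropyl in place of methyl on an oxygen gave a 1.8-fold lower number from compound 1 to compound 2 (0.25 log units; within the scatter), and methoxy in place of dimethylamino gave a 2.1-fold lower number from compound 2 to compound 3 (0.33 log units; beyond the scatter). Going by the values given here, with steps of that size as the only guide, no step beyond the scatter is expected in this assay, and neither direction is favoured, although this swap itself remains untested. The expected change is a 1.1-fold lower number from compound 2 to compound 4 (0.05 log units; within the scatter). The estimate for compound 4 is 45000 nM, with an expected range from 18000 nM to 100000 nM.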

Compound 4, half-maximal cytotoxic concentration: 80600 nM
The estimate for compound 4 lay 1.8-fold (0.25 log units) below the measured number; low and high end bracket the measured number.
By their numbers in this assay, from the lowest: compound 3; then compounds 2, 4 and 1 (each within the scatter of the next).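

Going by these compounds alone, this position, on an aromatic carbon ortho to an isopropoxy group, had not been varied in the earlier compounds, and the new step gives a first reading of it: in this assay the swap of nitro for propanoylamino gives a 1.6-fold higher number from compound 2 to compound 4 (0.21 log units; within the scatter). The nitro group is therefore not required for the cell tolerance seen here, since a group with a different make-up can take its place without a step beyond the scatter. Within the data shown here, the incoming group has more heavy atoms and carries a hydrogen-bond donor that nitro lacks, yet the data show only that this particular exchange leaves the number within the scatter, and nothing available explains that outcome.

The compounds shown leave open whether other groups at this carbon, such as a free amine, a carboxylic acid or a longer acyl chain than propanoylamino, would also stay within the scatter. They also leave open whether the same exchange would behave alike on the methoxy ether of compound 1, or with the methoxy in place of dimethylamino found in compound 3.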